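The source may report more compounds than this note shows. Statements on the series, on what has been measured and on what is new or still open speak of the compounds shown alone.

Measured so far:
Compound 1 `CCCCOC(=O)CNC(=O)[C@H](CSc1ccc([N+](=O)[O-])cc1[N+](=O)[O-])NC(=O)CC[C@H](NC(=O)CC(C)(C)C)C(=O)OCCCC` — in a toxicity assay on KB cells (Homo sapiens) for cytotoxicity, read by fluorescence, with a stated time of 3 days (a higher number here means that more compound is needed for the effect, a lower number that less compound is needed), compound 1 gives 250 uM.
Compound 2 `CCCCOC(=O)CNC(=O)[C@H](CSc1ccc([N+](=O)[O-])cc1[N+](=O)[O-])NC(=O)CC[C@H](Nc1ccc([N+](=O)[O-])cc1[N+](=O)[O-])C(=O)OCCCC` — compound 2 gives > 300 uM, which is a limit of the assay, not a number.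

Compound 2 thus stands at the limit of > 300 uM in this assay, at which 1 of the 2 values shown sits, so its position on the numbers is known only as that limit. Compound 3 `CCCCOC(=O)CNC(=O)[C@H](CSc1ccc([N+](=O)[O-])cc1[N+](=O)[O-])NC(=O)CC[C@H](NC(=O)C(C)(C)C)C(=O)OCCCC` differs from compound 2 by (tert-butyl)carbonyl in place of 2,4-dinitrophenyl on an amine nitrogen. Within the data shown here, the one measured step that bears on this is an at least 1.2-fold higher number from compound 1 to compound 2 (0.07 log units; that floor lies within the scatter), and compound 3 resembles compound 1 far more than compound 2. The change is therefore expected to undo that step, giving an at least 1.2-fold lower number from compound 2 to compound 3 (0.07 log units; that floor lies within the scatter). Compound 3 is expected near 250 uM, within 120 uM to 500 uM.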

Compound 3, concentration for half-maximal effect: 83.4 uM
Estimate against measurement, compound 3: 3.0-fold (0.48 log units) above, and the stated range ends above it.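

In this assay, among these compounds, the earlier compounds showed no step beyond the scatter, whereas a small change within the acyl group on this amine nitrogen now does: tert-butyl in place of neopentyl on a carbonyl carbon gives a 3.0-fold lower number from compound 1 to compound 3 (0.48 log units; beyond the scatter). Exchanging 2,4-dinitrophenyl for (tert-butyl)carbonyl gives an at least 3.5-fold lower number from compound 2 to compound 3 (0.55 log units; beyond the scatter). Compound 2 gives a limit of the assay, so that step is only a floor: the limit of > 300 uM in this assay, at which 1 of the 3 values shown sits.

From the compounds shown here alone, whether an acetyl group or a longer chain on this nitrogen would lower the number further remains open. So does the effect of a carboxylic acid there.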